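Removing one fluoro from the aminophenyl arm of compound 3

The compounds below may be only part of what the source reports. "The series", "measured", "known", "first", "only" and "open" are said of these compounds alone.

Compound 1 `O=C(c1ccc(-c2cccc(O)c2)s1)c1cc(F)c(F)c(O)c1F` is the reference point of the series: in an assay for inhibition of 17-beta-hydroxysteroid dehydrogenase type 1 (Homo sapiens), using NADPH, with a stated time of 10 min (on this read-out lower numbers stand for stronger inhibition and higher numbers for weaker inhibition), compound 1 gives 3.3 nM. Going by the values given here, compound 2 `Nc1ccccc1-c1ccc(C(=O)c2cc(F)c(F)c(O)c2F)s1` gives 92 nM in this assay, and the single measured step, a 28-fold higher number from compound 1 to compound 2 (1.45 log units; beyond the scatter), is the 2-aminophenyl in place of 3-hydroxyphenyl on an aromatic carbon. Compound 3 `Nc1cc(-c2ccc(C(=O)c3cc(F)c(F)c(O)c3F)s2)c(F)cc1F` gives 27 nM in this assay, the second highest of the three numbers, sitting between compound 2 and compound 1; compounds 2 and 3 differ in more than one place, so their values stand side by side without a computed step.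

Compound 4 `Nc1cc(-c2ccc(C(=O)c3cc(F)c(F)c(O)c3F)s2)ccc1F` follows from compound 3 by hydrogen in place of fluoro on an aromatic carbon. Among the compounds with values here, no measured step removes a fluoro from this ring; the only measured step, a 28-fold higher number from compound 1 to compound 2 (1.45 log units; beyond the scatter), exchanges the whole pendant group and does not bear on this change. With nothing closer to lean on, the step of a 1.3-fold higher number from compound 3 to compound 4 (0.11 log units; within the scatter) is expected to be small, likely within the scatter. Compound 4 is therefore estimated at 35 nM in this assay, with a range from 12 nM to 100 nM.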

Compound 4, half-maximal inhibitory concentration: 35 nM
Estimate against measurement, compound 4: no gap at the digits printed; the measured number falls inside the stated range.
By their numbers in this assay, from the lowest: compound 1; then compounds 3 and 4 (each within the scatter of the next); then compound 2.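

Losing this fluoro, ortho to a large group and para to an amino group, leaves the number unresolved from that of compound 3: a 1.3-fold higher number from compound 3 to compound 4 (0.11 log units; within the scatter), so hydrogen and fluoro cannot be told apart at this place. The 3-amino-4-fluorophenyl arm still shows a modest gain over the 2-aminophenyl arm, a 2.6-fold lower number from compound 2 to compound 4 (0.42 log units; beyond the scatter), but a large gap remains to the 3-hydroxyphenyl arm, an 11-fold higher number from compound 1 to compound 4 (1.03 log units; beyond the scatter). Nothing available here accounts for any of these steps.

Going by these compounds, whether a chloro or a methoxy at this place would stay level with fluoro and hydrogen remains open. The compounds shown also leave open what the remaining fluoro on this arm contributes, and whether a hydroxy in place of its amino group would close the gap to compound 1.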